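Amide substituent changes on a shared core: expected potency of compound 4

The compounds below may be only part of what the source reports. "The series", "measured", "known", "first", "only" and "open" are said of these compounds alone.

Measured compounds:
compound 1 `CCn1c(C(=O)NCCN(C)C)ccc1C(CC)(CC)c1ccc(OCCC(O)(CC)CC)c(C)c1`: 870 nM
compound 2 `C=CCN(C)C(=O)c1ccc(C(CC)(CC)c2ccc(OCCC(O)(CC)CC)c(C)c2)n1CC`: 12800 nM
compound 3 `CCOC(=O)C(CC(=O)OC)NC(=O)c1ccc(C(CC)(CC)c2ccc(OCCC(O)(CC)CC)c(C)c2)n1CC`: 5840 nM

In a functional assay on PC-3 cells (Homo sapiens) for antiproliferative activity, read by MTT assay, with a stated time of 48 h (on this read-out higher numbers stand for weaker inhibition and lower numbers for stronger inhibition), compound 2 gives the highest number of the three, so it is the weakest inhibitor shown. Compound 4 `CCC(C)C(CO)NC(=O)c1ccc(C(CC)(CC)c2ccc(OCCC(O)(CC)CC)c(C)c2)n1CC` differs from compound 2 in one place: (1-(hydroxymethyl)-2-methylbutyl)amino in place of allyl(methyl)amino on a carbonyl carbon. Among the measured compounds shown here, two measured steps bear on this change. The step of a 15-fold higher number from compound 1 to compound 2 (1.17 log units; beyond the scatter) shows that replacing an amide bearing a hydrogen with the allyl(methyl)amino group raised the number a great deal. The step of a 2.2-fold lower number from compound 2 to compound 3 (0.34 log units; beyond the scatter) shows that going back to an amide with a hydrogen, though carrying a larger group, brought the number down only modestly. Compound 4 again carries an amide hydrogen together with a hydroxyl, so a lower number than compound 2 is expected, of a size between those two steps, giving an expected step of a 4.3-fold lower number from compound 2 to compound 4 (0.63 log units; beyond the scatter). Compound 4 is therefore estimated at 3000 nM, with a range from 1200 nM to 8000 nM.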

Compound 4, half-maximal inhibitory concentration: 28400 nM
Estimate against measurement, compound 4: 9.5-fold (0.98 log units) below; the whole stated range lies below it.
By their numbers in this assay, from the lowest: compound 1; then compound 3; then compound 2; then compound 4.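

Putting (1-(hydroxymethyl)-2-methylbutyl)amino in place of allyl(methyl)amino on the carbonyl carbon gave a 2.2-fold higher number from compound 2 to compound 4 (0.35 log units; beyond the scatter) in this assay, so the amide hydrogen alone does not lower the number at this position. The compounds that carry that hydrogen also spread widely among themselves, with a 4.9-fold higher number from compound 3 to compound 4 (0.69 log units; beyond the scatter) and a 33-fold higher number from compound 1 to compound 4 (1.51 log units; beyond the scatter), which leaves compound 4 as the weakest of the four and shows that the group on the amide-type nitrogen can move the number in either direction. Nothing measured here accounts for the hydroxyl-bearing chain giving the highest number.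

A plain 2-methylbutyl on the same nitrogen would separate the effect of the branched chain from that of the hydroxymethyl. As far as these compounds go, whether the 2-(dimethylamino)ethyl chain of compound 1 owes its low number to its terminal amine remains open, and a 2-methoxyethyl or a 3-(dimethylamino)propyl chain would bear on that question.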